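This account rests on a few compounds, and the source may have more. Where it says the series, first, only, none or still open, it means among the compounds named here.

Three members of the series carry the same core and differ only in the aryl group on the saturated carbon. Compound 1 `CC(=O)N1N=C(c2ccc(-n3nc(C)n(N)c3=O)cc2)CC1c1ccccc1` gives 129% in an assay on isolated protein for inhibition of pancreatic alpha-amylase (Homo sapiens), with a stated time of 10 min, tested at 1 mg/mL; on this read-out higher numbers stand for more inhibition at the one concentration tested (going by the name of the read-out) and lower numbers for less inhibition. Compound 2 `CC(=O)N1N=C(c2ccc(-n3nc(C)n(N)c3=O)cc2)CC1c1ccc(C)cc1` gives 96.5%, and compound 3 `COc1ccc(C2CC(c3ccc(-n4nc(C)n(N)c4=O)cc3)=NN2C(C)=O)cc1` gives 96.5%; compound 3 thus stands level with compound 2, the two together at the low end of the three numbers, and a number 32.5 percentage points lower from compound 1 to compound 3 (beyond the scatter) mirrors a number 32.5 percentage points lower from compound 1 to compound 2 (beyond the scatter). Compound 4 `CC(=O)N1N=C(c2ccc(-n3nc(C)n(N)c3=O)cc2)CC1c1ccc(Cl)cc1` continues the step with chloro in place of methoxy on an aromatic carbon. Going by the values given here, the one comparison bearing on it is the swap between substituents on that ring, no change at the digits printed from compound 2 to compound 3 (within the scatter), so for compound 4 a step of a number 0.5 percentage points lower from compound 3 to compound 4 (within the scatter) is expected, none beyond the scatter. Compound 4 is estimated at 96%, within 78% to 118%.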

Compound 4, a percentage reported as inhibition, at one concentration (the size of the read-out at that concentration, not a potency): 126%
Estimate against measurement, compound 4: 30 percentage points below; measured number above the stated range.
By their numbers in this assay, from the lowest: compounds 2 and 3 (each within the scatter of the next); then compounds 4 and 1 (each within the scatter of the next).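

The place on the aromatic ring does not respond alike to all substituents: chloro in place of methoxy gives a number 29.5 percentage points higher from compound 3 to compound 4 (beyond the scatter) and chloro in place of methyl gives a number 29.5 percentage points higher from compound 2 to compound 4 (beyond the scatter) in this assay even though methyl and methoxy were not separated. Chloro in place of hydrogen gives a number 3 percentage points lower from compound 1 to compound 4 (within the scatter) so a substituent here does not in itself lower the number. Nothing available explains why chloro parts from methyl and methoxy.

From the compounds shown here alone, whether fluoro, bromo or trifluoromethyl reads like chloro remains open. So does the reading for an amine or a carboxylic acid at this place.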